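Three Limits and One Missing Side Group

The source may report more compounds than this note shows. Statements on the series, on what has been measured and on what is new or still open speak of the compounds shown alone.

Measured in a functional assay on Raji cells (Homo sapiens) for cytotoxicity, with a stated time of 72 h (a higher number here means that more compound is needed for the effect, a lower number that less compound is needed), so far:
Compound 1 `C=C[C@@](C)(/C=C/c1ccc(O)cc1)CC/C=C(\C)CO` gives > 26000 nM as a limit
Compound 2 `C=C[C@@](C)(/C=C/c1ccc(O)c(/C=C/C#N)c1)CCC=C(C)C` gives > 26000 nM as a limit
Compound 3 `COc1ccc(/C=C/[C@@](C)(/C=C/c2ccc(O)c(/C=C/C#N)c2)CCC=C(C)C)cc1` gives > 26000 nM as a limit

Compound 3 has no number of its own in this assay, and neither do the other two compounds. All three stand at the limit of > 26000 nM in this assay, at which 3 of the 3 values shown sit, and so cannot be ordered among themselves. Compound 4 `COc1ccc(/C=C/[C@@](C)(/C=C/c2ccc(O)cc2)CCC=C(C)C)cc1` has hydrogen in place of 2-cyanoethenyl on an aromatic carbon and is otherwise the same as compound 3.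

Within the data shown here, no measured step covers this change directly. Among the measured compounds shown here, the only single-place step is a step that the two limits leave unreadable from compound 2 to compound 3 and it concerns the vinyl place, not the 2-cyanoethenyl. Compound 1, which carries hydrogen on the aromatic carbon in question, gives > 26000 nM as a limit, although its chain differs from that of compound 4. With no readable step to draw on, no step beyond the scatter and no direction is expected, and compound 4 will most likely report a limit too.

For compound 4 the estimated value is 26000 nM with an expected range from 9000 nM to 50000 nM in this assay. The expected step is a number no higher from compound 3 to compound 4 (the limit leaves the size open) and it remains an estimate set against a limit.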

Compound 4, half-maximal effective concentration: > 26000 nM
Compound 4: a limit, no number; the forecaster's own chance of this, stated with the estimate: 80%; the middle value lies on the limit itself.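

Compound 4 also reports a limit and not a number, so the step from compound 3 to compound 4 cannot be read and the two compounds cannot be ordered: the limit of > 26000 nM in this assay, at which 4 of the 4 values shown sit. What the compounds shown leave open in this assay is whether hydrogen in place of 2-cyanoethenyl, or any other change among them, alters the effect at all.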